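The source may hold more compounds than are shown below. What is called first, only, known or untested is meant among the compounds shown, and "the series" means these compounds.

In a functional assay on MGC-803 cells (Homo sapiens) for inhibition, read by sulforhodamine B assay (on this read-out higher numbers stand for weaker inhibition and lower numbers for stronger inhibition), compound 1 (`O=C1C(Nc2ccc(I)cc2)=CC(=O)c2c1nc1n2[C@H]2OC[C@@H](O)[C@H]2OC1`) gives 2150 nM. Compound 2 (`O=C1C(NC2CCCCC2)=CC(=O)c2c1nc1n2[C@H]2OC[C@@H](O)[C@H]2OC1`) stands only at a limit of the assay, > 8000 nM, and not at a number. Among the measured compounds shown here, the one measured step bearing on the next change, cyclohexyl in place of 4-iodophenyl on an amine nitrogen, is an at least 3.7-fold higher number from compound 1 to compound 2 (0.57 log units; beyond the scatter). Compound 3 (`O=C1C(Nc2cccc(Cl)c2)=CC(=O)c2c1nc1n2[C@H]2OC[C@@H](O)[C@H]2OC1`) has 3-chlorophenyl in place of cyclohexyl on an amine nitrogen. This restores an aromatic ring at that nitrogen, so compound 1 at 2150 nM serves as the guide and a lower number is expected in this assay. The expected step is an at least 2.6-fold lower number from compound 2 to compound 3 (0.42 log units; beyond the scatter). The estimate for compound 3 is 3000 nM, with an expected range of 1100 nM to 8000 nM.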

Compound 3, half-maximal inhibitory concentration: 1530 nM
Compound 3: the middle estimate sits 2.0-fold (0.29 log units) above what was measured; the range from low to high includes it.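

In this assay, the change to 3-chlorophenyl on the amine nitrogen gives an at least 5.2-fold lower number from compound 2 to compound 3 (0.71 log units; beyond the scatter), so a second aryl group, after the 4-iodophenyl of compound 1, reads clearly stronger than cyclohexyl. Compound 2 stands at a limit and not at a number, which leaves the size of that step open-ended: the limit of > 8000 nM in this assay, at which 1 of the 3 values shown sits. The two aryl groups are not told apart, with a 1.4-fold lower number from compound 1 to compound 3 (0.15 log units; within the scatter), so swapping 4-iodophenyl for 3-chlorophenyl moves nothing that can be read here.

Open, from the compounds shown here alone, is whether plain phenyl, with no halogen, holds this level. Also open, going by these compounds, is how a benzyl group or a methoxyphenyl group on that nitrogen would read.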